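A few compounds are considered here, and "the series" means these few. Any claim that something is new, unique, unknown or untested is made for them only; others in the source may bear on it.

Compound 1, with the structure `CN1C[C@H]2CCCC[C@@]2(Cc2ccc(Cl)c(Cl)c2)C1`, is one of two compounds with a number in an assay on CHO-K1 cells for inhibition of sodium-dependent dopamine transporter (Homo sapiens) (a lower number here means a stronger inhibitor, a higher number a weaker inhibitor), where compound 1 gives 479 nM. Compound 2, with the structure `CN1C[C@@H]2CCC[C@]2(c2ccc3ccccc3c2)C1`, gives 100 nM; 182 nM (2 entries) in this assay. Compound 3, with the structure `Clc1ccc(C[C@@]23CCCC[C@@H]2CNC3)cc1Cl`, differs from compound 1 by hydrogen in place of methyl on an amine nitrogen in a ring. Among the compounds with values here, no measured pair shows this change, so no step beyond the usual scatter is expected in either direction. Compound 3 is therefore estimated at 420 nM, between 130 nM and 1300 nM, which would mean a step of a 1.1-fold lower number from compound 1 to compound 3 (0.06 log units; within the scatter).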

Compound 3, half-maximal inhibitory concentration: 158 nM
Compound 3: the middle estimate sits 2.7-fold (0.42 log units) above what was measured; the measured number falls inside the stated range.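

Swapping methyl for hydrogen on the amine nitrogen in a ring gives the first measured step at this position: in this assay, the change brings a 3.0-fold lower number from compound 1 to compound 3 (0.48 log units; beyond the scatter). So, within this one pair, the methyl is not needed for inhibition, and removing it gives a stronger inhibitor. Repeat entries give a sense of how much numbers vary in this assay: the several entries of compound 2 in this assay, 100 nM; 182 nM (2 entries)

This single pair cannot show whether the same change would act alike on another core, such as that of compound 2. As far as these compounds go, how an ethyl group or a longer chain on this nitrogen would compare also remains open.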